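Taking the ethoxy group off compound 3

A few compounds are considered here, and "the series" means these few. Any claim that something is new, unique, unknown or untested is made for them only; others in the source may bear on it.

Values in a functional assay on PC-12 cells (Rattus norvegicus) for inhibition, read by sulforhodamine B assay (on this read-out higher numbers stand for weaker inhibition and lower numbers for stronger inhibition), as measured so far:
Compound 1 `O=C1NC(=O)C(Cc2ccc(OCC3CC3)cc2)S1` gives > 100000 nM as a limit
Compound 2 `CCC(C)(C)Oc1ccc(CC2SC(=O)NC2=O)cc1` gives 23000 nM as a number
Compound 3 `CCOc1ccc(CC2SC(=O)NC2=O)cc1` gives > 100000 nM as a limit

In this assay compound 3 stands at > 100000 nM as a limit, not a number. It is one of the compounds at the limit of > 100000 nM in this assay, at which 2 of the 3 values shown sit, and only compound 2 gives a number.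

The next structure is compound 4 `O=C1NC(=O)C(Cc2ccccc2)S1` and the change is hydrogen in place of ethoxy on an aromatic carbon.

The measured steps that bear on this are changes to the group on the same oxygen. One is an at least 4.3-fold higher number from compound 2 to compound 3 (0.63 log units; beyond the scatter) with ethyl in place of 1,1-dimethylpropyl. Another is an at least 4.3-fold lower number from compound 1 to compound 2 (0.63 log units; beyond the scatter) with 1,1-dimethylpropyl in place of cyclopropylmethyl. Both lie beyond the scatter, and both run toward weaker inhibition as the 1,1-dimethylpropyl group is lost or toward stronger inhibition as it is gained. The third, a step that the two limits leave unreadable from compound 1 to compound 3, gives no readable size. Compound 2 alone reaches a number, 23000 nM in this reading. Within the data shown here, with the ethoxy group gone too, no step toward stronger inhibition beyond the scatter is expected in this assay and another limit is the likeliest report. The expected step is a step that the limit leaves unreadable from compound 3 to compound 4 as an estimate. For compound 4 the estimated value is 130000 nM with an expected range from 50000 nM to 300000 nM in this estimate.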

Compound 4, half-maximal inhibitory concentration: > 100000 nM
Compound 4 gave a limit, no number (the forecaster's own chance of this, stated with the estimate: 80%); the middle value is on the limit's open side.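

In this assay compound 4 carries only hydrogen on the aromatic carbon para to a group of 8 heavy atoms, and it gives > 100000 nM, which is a limit and not a number. Hydrogen in place of 1,1-dimethylpropoxy gives an at least 4.3-fold higher number from compound 2 to compound 4 (0.63 log units; beyond the scatter), so the number seen for compound 2 is lost not only with a smaller group on the oxygen but also with no such group on this carbon at all. The steps from compound 3 and from compound 1 to compound 4 cannot be read, since both ends are limits, and the series now rests on a single number and a shared ceiling: the limit of > 100000 nM in this assay, at which 3 of the 4 values shown sit.

Going by these compounds, how far compound 1, compound 3 and compound 4 differ from one another beyond that limit stays unknown, so the ethoxy and cyclopropylmethoxy groups cannot be ranked against hydrogen. On these data alone, whether the gain belongs to 1,1-dimethylpropoxy alone is also open, as is what a longer chain on the same oxygen, or an amine or a carboxylic acid on this aromatic carbon, would give.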